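Compound 2 to compound 4: a chain exchange

The source may hold more compounds than are shown below. What is called first, only, known or untested is meant among the compounds shown, and "the series" means these compounds.

Values in a functional assay on HCT-116 cells (Homo sapiens) for antiproliferative activity, read by sulforhodamine B assay, with a stated time of 72 h (a lower number here means a stronger inhibitor, a higher number a weaker inhibitor), for the measured compounds
- compound 1 `Cn1ncc(Cl)c1-c1cc(C(=O)N[C@@H]2CN[C@H](CC(O)CO)C[C@H]2c2ccc(F)c(F)c2)oc1Cl` gives 800 nM
- compound 2 `Cn1ncc(Cl)c1-c1cc(C(=O)N[C@@H]2CN[C@H](CC(O)CO)C[C@H]2c2ccc(Cl)c(Cl)c2)oc1Cl` gives 1110 nM
- compound 3 `Cn1ncc(Cl)c1-c1cc(C(=O)N[C@@H]2CNCC[C@H]2c2ccc(C(F)(F)F)cc2)oc1Cl` gives 280 nM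

Compound 2 lies within the scatter of compound 1 and carries a higher number than compound 3, by more than the scatter. Compound 4 `Cn1ncc(Cl)c1-c1cc(C(=O)N[C@@H]2CN[C@H](CCn3cncn3)C[C@H]2c2ccc(Cl)c(Cl)c2)oc1Cl` follows from compound 2 with the change (1H-1,2,4-triazol-1-yl)methyl in place of 1,2-dihydroxyethyl on a saturated chain carbon bound to a saturated ring carbon which puts (1H-1,2,4-triazol-1-yl)methyl in place of 1,2-dihydroxyethyl on a saturated chain carbon bound to a saturated ring carbon. Among the compounds with values here, the one measured step (a 1.4-fold higher number from compound 1 to compound 2 (0.14 log units; within the scatter)) puts 3,4-dichlorophenyl in place of 3,4-difluorophenyl and lies within the scatter. It leaves the chain untouched, so it bears on this change only indirectly. Compound 3 lacks the chain but also differs from compound 2 in its aryl group, so its gap cannot be assigned to the chain alone. Within the data shown here, no measured step changes this chain. No step beyond the scatter is therefore expected, and the estimate is a 1.4-fold lower number from compound 2 to compound 4 (0.14 log units; within the scatter) with its direction uncertain. In this assay the expected value for compound 4 is 800 nM within an estimated range from 280 nM to 2200 nM for now.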

Compound 4, half-maximal inhibitory concentration: 560 nM
Compound 4: middle estimate off by 1.4-fold (0.15 log units), on the high side, and the stated range covers the measured number.
By their numbers in this assay, from the lowest: compounds 3, 4, 1 and 2 (each within the scatter of the next, the first and the last beyond it).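

In this assay, within the data shown here, the exchange of 1,2-dihydroxyethyl for (1H-1,2,4-triazol-1-yl)methyl on a saturated chain carbon bound to a saturated ring carbon gives a 2.0-fold lower number from compound 2 to compound 4 (0.30 log units; within the scatter) and is the first measured step at this chain. With the 3,4-dichlorophenyl group held fixed, this position therefore accepts the loss of both hydrogen-bond donors of the 1,2-dihydroxyethyl group and the entry of a five-membered aromatic ring with 3 hetero atoms, without a step beyond the scatter. No measurement available on these compounds explains this result.

On these data alone, whether the same exchange gives a similar step with the 3,4-difluorophenyl group of compound 1 remains open. Also open, as far as these compounds go, is how an amine, a carboxylic acid or a longer chain in this place would read in this assay against these two chains.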